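The source may report more compounds than this note shows. Statements on the series, on what has been measured and on what is new or still open speak of the compounds shown alone.

Measured in a functional assay on HCT-116 cells (Homo sapiens) for antiproliferative activity, read by MTT assay, with a stated time of 48 h; a higher number here means a weaker inhibitor, a lower number a stronger inhibitor:
Compound 1 `O=C(Nc1cccc(/C=C/C(=O)c2nc3ccccc3[nH]2)c1)c1cccc(Cl)c1` gives 1120 nM.
Compound 2 `O=C(/C=C/c1cccc(NC(=O)c2ccccc2Br)c1)c1nc2ccccc2[nH]1` gives 1680 nM.
Compound 3 `O=C(Nc1cccc(/C=C/C(=O)c2nc3ccccc3[nH]2)c1)c1ccc(Br)cc1` gives 2230 nM.

Among these three numbers compound 2 stands second highest; its nearest neighbour is compound 3, with a 1.3-fold higher number from compound 2 to compound 3 (0.12 log units; within the scatter), and the furthest is compound 1, with a 1.5-fold higher number from compound 1 to compound 2 (0.18 log units; within the scatter). Compound 4 `Cc1ccc(C(=O)Nc2cccc(/C=C/C(=O)c3nc4ccccc4[nH]3)c2)cc1` is not yet measured. It differs from compound 2 in one place: 4-methylphenyl in place of 2-bromophenyl on a carbonyl carbon. Among the compounds with values here, the steps that bear on this are the three swaps of the aryl group on that carbonyl carbon: a 1.5-fold higher number from compound 1 to compound 2 (0.18 log units; within the scatter), a 2.0-fold higher number from compound 1 to compound 3 (0.30 log units; within the scatter) and a 1.3-fold higher number from compound 2 to compound 3 (0.12 log units; within the scatter), each within the scatter. Within these compounds that aryl group has made little difference, so no step beyond the scatter is expected in this assay. For compound 4 the expected step is a 1.0-fold higher number from compound 2 to compound 4 (0.01 log units; within the scatter). Compound 4 is estimated at 1700 nM, with a range from 700 nM to 4000 nM.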

Compound 4, half-maximal inhibitory concentration: 1660 nM
Estimate against measurement, compound 4: 1.0-fold (0.01 log units) above; low and high end bracket the measured number.
By their numbers in this assay, from the lowest: compounds 1, 4, 2 and 3 (each within the scatter of the next).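

In this assay a halogen on this aryl group proves not to be required, as 4-methylphenyl, which carries none, stays within the scatter of all three halogen-bearing compounds: a 1.0-fold lower number from compound 2 to compound 4 (0.01 log units; within the scatter) and a 1.3-fold lower number from compound 3 to compound 4 (0.13 log units; within the scatter) and a 1.5-fold higher number from compound 1 to compound 4 (0.17 log units; within the scatter) all say the same. Nothing measured here explains why these aryl groups read alike.

Every group shown at this place is a phenyl ring with one small substituent. Going by these compounds, whether an amine, a carboxylic acid or a longer chain on that ring would also leave the number unchanged remains open.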